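Cytotoxicity notes on one series, compound 4 pending

The compounds below may be only part of what the source reports. "The series", "measured", "known", "first", "only" and "open" are said of these compounds alone.

Compound 1 `CN1CCN(CC(=O)Nc2ccc(-c3nc4cc(Cl)c(Cl)cc4[nH]3)cc2)CC1`: in an ADME assay on Vero cells (Chlorocebus sabaeus) for cytotoxicity (on this read-out lower numbers stand for higher toxicity in this test and higher numbers for lower toxicity in this test), compound 1 reports > 100000 nM, which is a limit of the test and not a number.
Compound 2 `COc1ccc(-c2nc3cc([N+](=O)[O-])ccc3[nH]2)c(OC)c1OC`: in this assay compound 2 reports > 100000 nM, again a limit.
Compound 3 `CC(=O)Nc1ccc(-c2nc3cc([N+](=O)[O-])ccc3[nH]2)cc1`: in this assay compound 3 reports > 100000 nM, also a limit.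

Compound 1 therefore stands at the ceiling of what this assay reports, together with the two other measured compounds, since all three values sit at the limit of > 100000 nM in this assay, at which 3 of the 3 values shown sit. Among the compounds with values here, no compound can be placed above or below another on these numbers, and no step between measured compounds can be taken from them.

Compound 4 `CC(=O)Nc1ccc(-c2nc3cc(Cl)c(Cl)cc3[nH]2)cc1` is not yet measured. It differs from compound 1 by hydrogen in place of 4-methylpiperazin-1-yl on a saturated chain carbon bound to a carbonyl carbon. Within the data shown here, no measured pair shows this change, so its effect on cytotoxicity is not known from the series itself.

The step from compound 1 to compound 4 is expected to be a number no higher from compound 1 to compound 4 (the limit leaves the size open), that is, no change beyond the scatter of the test. Compound 4 is estimated at 100000 nM. For compound 4 the expected range runs from 40000 nM to 250000 nM. Because compound 1 sits at the limit of > 100000 nM in this assay, at which 3 of the 3 values shown sit, the most likely report for compound 4 is once more a limit rather than a number.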

Compound 4, half-maximal cytotoxic concentration: > 100000 nM
Compound 4 ended at the assay's limit (the forecaster's own chance of this, stated with the estimate: 85%); the middle value lies on the limit itself.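

In this assay compound 4 gives > 100000 nM, a limit of the test and not a number. Compound 1 and compound 4 both stand at a limit, and no step can be read between them. Left open is the concentration at which any of the compounds shown becomes cytotoxic, and whether hydrogen in place of 4-methylpiperazin-1-yl alters it.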